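The source may report more compounds than this note shows. Statements on the series, on what has been measured and on what is new or still open speak of the compounds shown alone.

Compound 2 `COc1cccc(F)c1C1CCN(c2ccn3c(CC4CC4)nnc3c2Cl)CC1` gives 11.2 nM in an assay on CHO cells for displacement of a labelled ligand from metabotropic glutamate receptor 2 (Homo sapiens), read by scintillation counting, with a stated time of 60 min (on this read-out lower numbers stand for stronger inhibition and higher numbers for weaker inhibition), level with compound 1 `COc1ccc(F)cc1C1CCN(c2ccn3c(CC4CC4)nnc3c2Cl)CC1`, which gives 11.2 nM. Within the data shown here, the one step measured so far, no change at the digits printed from compound 1 to compound 2 (within the scatter), swapped the fluoro and methoxy groups around the ring without any effect beyond the scatter. Compound 3 `COc1c(F)ccc(F)c1C1CCN(c2ccn3c(CC4CC4)nnc3c2Cl)CC1` differs from compound 2 by fluoro in place of hydrogen on an aromatic carbon. Among the measured compounds shown here, no measured step adds a fluoro to an already substituted ring. For the measured compounds named here, the only guide is the flat step no change at the digits printed from compound 1 to compound 2 (within the scatter). Compound 3 is therefore expected to show no shift beyond the scatter, a 1.0-fold lower number from compound 2 to compound 3 (0.01 log units; within the scatter). The estimate for compound 3 is 11 nM, within 5 nM to 25 nM.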

Compound 3, half-maximal inhibitory concentration: 9.23 nM
Compound 3: the middle estimate sits 1.2-fold (0.08 log units) above what was measured; low and high end bracket the measured number.
By their numbers in this assay, from the lowest: compounds 3, 1 and 2 (each within the scatter of the next).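

Adding a fluoro on the aromatic carbon ortho to a methoxy group and para to a fluoro group gives a 1.2-fold lower number from compound 2 to compound 3 (0.08 log units; within the scatter) in this assay, so this place takes a second fluoro on the ring with no shift beyond the scatter. The 3,6-difluoro-2-methoxyphenyl group likewise gives a 1.2-fold lower number from compound 1 to compound 3 (0.08 log units; within the scatter), staying level with the 5-fluoro-2-methoxyphenyl group. No evidence is available that bears on these flat results. The compounds shown leave open whether a chloro, a nitrile or an amine on this same carbon would also stay within the scatter.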